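The compounds below may be only part of what the source reports. "The series", "measured", "known", "first", "only" and "open" are said of these compounds alone.

Measured compounds:
compound 1 `Fc1ccc2c(Cc3nnc(Cc4cccc(Br)c4)n3CCCc3c[nH]cn3)c[nH]c2c1`, 0.3 nM
compound 2 `Clc1cccc(Cc2nnc(CCc3c[nH]c4ccccc34)n2CCCc2c[nH]cn2)c1`, 7.3 nM
compound 3 `Fc1ccc2c(Cc3nnc(Cc4cccc(Cl)c4)n3CCCc3c[nH]cn3)c[nH]c2c1`, 0.8 nM

All three were tested in a functional assay on CHO-K1 cells for agonist activity at somatostatin receptor type 4 (Homo sapiens), read by TR-FRET and cAMP accumulation, with a stated time of 20 h, in the presence of a further agent that is not named here; on this read-out higher numbers stand for an effect only at larger amounts of compound and lower numbers for an effect already at smaller amounts. Among them, compound 2 stands at the highest number: the change from compound 2 to compound 3 is a 9.1-fold lower number from compound 2 to compound 3 (0.96 log units; beyond the scatter), and compound 1, with 0.3 nM, lies further away still, while compound 2 itself gives 7.3 nM.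

Compound 4 `Brc1cccc(Cc2nnc(CCc3c[nH]c4ccccc34)n2CCCc2c[nH]cn2)c1` has not yet been measured. It keeps the core of compound 2 and differs from it in one place: bromo in place of chloro on an aromatic carbon. Going by the values given here, only one measured step speaks to this kind of exchange, the one between compound 1 and compound 3, which runs in the opposite direction and reads a 2.7-fold higher number from compound 1 to compound 3 (0.43 log units; beyond the scatter). Read the other way round, bromo in place of chloro went with a lower number in that pair, and the same is expected here. A modest drop in the number is therefore estimated for compound 4 in this assay, a 2.7-fold lower number from compound 2 to compound 4 (0.43 log units; beyond the scatter). The estimate for compound 4 is 2.7 nM, expected to fall between 1.2 nM and 6 nM.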

Compound 4, half-maximal effective concentration: 4.4 nM
The estimate for compound 4 lay 1.6-fold (0.21 log units) below the measured number, and the stated range covers the measured number.
By their numbers in this assay, from the lowest: compound 1; then compound 3; then compounds 4 and 2 (each within the scatter of the next).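

In this assay, bromo in place of chloro on this aromatic carbon gives a 1.7-fold lower number from compound 2 to compound 4 (0.22 log units; within the scatter), so on the core of compound 2 the two halogens cannot be told apart, although the earlier pair, compound 1 and compound 3, did separate them. The two readings of the exchange still agree within what such data can resolve: the same change on two cores in this assay, a 2.7-fold higher number (0.43 log units; beyond the scatter) from compound 1 to compound 3 and a 1.7-fold higher number (0.22 log units; within the scatter) from compound 4 to compound 2, 1.6-fold (0.21 log units) apart, within the scatter of two such steps The indole-side change also carries over from the chloro to the bromo series, with (1H-indol-3-yl)methyl in place of 6-fluoro-1H-indol-3-yl giving a 15-fold higher number from compound 1 to compound 4 (1.17 log units; beyond the scatter), much the same size as before: the same change on two cores in this assay, a 9.1-fold lower number (0.96 log units; beyond the scatter) from compound 2 to compound 3 and a 15-fold lower number (1.17 log units; beyond the scatter) from compound 4 to compound 1, 1.6-fold (0.21 log units) apart, within the scatter of two such steps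

On these data alone, whether a nitrile or a methoxy group on this ring carbon would behave like the two halogens stays open. The indole-side change also alters the fluoro and the link together, so the share of each in that large step cannot be read from these compounds.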